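Ethyl in Place of Acetyl: An Expected Cytotoxicity Step

The compounds below may be only part of what the source reports. "The series", "measured", "known", "first", "only" and "open" are said of these compounds alone.

Of the compounds shown here, three built on a shared core have been tested in a functional assay on KBVIN cells (Homo sapiens) for cytotoxicity, read by MTT assay, with a stated time of 72 h; a lower number here means that less compound is needed, a higher number that more compound is needed for the effect. Compound 1, with the structure `CCOc1c(-c2occ(C)c2C(=O)O)ccc2c(CC)cccc12`, shows only a limit of the assay rather than a number, namely > 10 ug/mL. Compound 2, with the structure `CCc1cccc2c(OC(C)=O)c(-c3occ(C)c3COC(C)=O)ccc12`, likewise reaches only a limit, > 10 ug/mL. Compound 3, with the structure `CCc1cccc2c(OC)c(-c3occ(C)c3CBr)ccc12`, also stops at a limit, > 10 ug/mL. So compound 2 stands exactly where the other two stand: at the limit of > 10 ug/mL in this assay, at which 3 of the 3 values shown sit, with nothing to separate the three.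

Compound 4, with the structure `CCOc1c(-c2occ(C)c2COC(C)=O)ccc2c(CC)cccc12`, has not yet been measured. It differs from compound 2 in one place: ethyl in place of acetyl on an oxygen on an aromatic ring. Among the compounds with values here, no measured pair tells how large such a change is here.

With every neighbour at the same limit, the step that the limit leaves unreadable from compound 2 to compound 4 is expected to stay within the usual scatter. Compound 4 is therefore expected to give about 15 ug/mL in this assay, with a range from 5 ug/mL to 40 ug/mL, and most likely again only a limit.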

Compound 4, concentration for half-maximal effect: 5.8 ug/mL
For compound 4 the middle estimate is 2.6-fold (0.41 log units) above the measured one; low and high end bracket the measured number.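

In this assay compound 4 gives a true number rather than a limit, which shows that compounds on this shared core can reach the measurable range. Compound 4 carries both ethoxy and acetoxymethyl, and changing either one leaves a compound at a limit: acetoxy for ethoxy is read as an at least 1.7-fold lower number from compound 2 to compound 4 (0.23 log units; that floor lies within the scatter), and carboxy for acetoxymethyl as an at least 1.7-fold lower number from compound 1 to compound 4 (0.23 log units; that floor lies within the scatter). Each step is only a floor, and its true size stays unknown, because one end of each pair is a limit and most of the set sits there: the limit of > 10 ug/mL in this assay, at which 3 of the 4 values shown sit.

The compounds shown leave open how far the group on the oxygen can be varied, for example with a longer chain such as butoxy. They also leave open whether an amine in place of the acetoxymethyl group would still give a number.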